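Replacing cyclobutylmethyl with 3-chloropyridin-2-yl on compound 1

This account rests on a few compounds, and the source may have more. Where it says the series, first, only, none or still open, it means among the compounds named here.

compound 1 `O=C(NCC1CCC1)N1CCC(c2nc(-c3ccc4ccccc4n3)no2)CC1` at 410 nM
compound 2 `Cn1c(-c2noc(C3CCN(C(=O)NC4CCS(=O)(=O)CC4)CC3)n2)nc2ccccc21` at 350 nM
compound 3 `Cn1c(-c2noc(N3CCN(C(=O)NC4CCCCC4)CC3)n2)nc2ccccc21` at 5 nM

All three compounds were tested in a functional assay on Shh Light II cells (Mus musculus) for inhibition, read by a luciferase reporter; on this read-out lower numbers stand for stronger inhibition and higher numbers for weaker inhibition. Compound 1 (410 nM) and compound 2 (350 nM) lie within the scatter of each other. Compound 3 (5 nM) has a much lower number than compound 1, well beyond the scatter. Compound 1 therefore sits at the high-number end of this small set, together with compound 2.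

The next compound is compound 4 `O=C(Nc1ncccc1Cl)N1CCC(c2nc(-c3ccc4ccccc4n3)no2)CC1`, which has 3-chloropyridin-2-yl in place of cyclobutylmethyl on an amide-type nitrogen. The core of compound 1 is unchanged. Going by the values given here, no measured pair shows this change on its own, so the expectation is loose. A moderate step towards a lower number is expected in this assay, although a step within the scatter cannot be ruled out. The expected change is a 2.7-fold lower number from compound 1 to compound 4 (0.44 log units; beyond the scatter) in size. The estimate for compound 4 is 150 nM (estimated range 30 nM to 700 nM).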

Compound 4, half-maximal inhibitory concentration: 2800 nM
For compound 4 the middle estimate is 19-fold (1.27 log units) below the measured one, outside the stated range (above it).
By their numbers in this assay, from the lowest: compound 3; then compounds 2 and 1 (each within the scatter of the next); then compound 4.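

Going by these compounds alone, the first comparison in one place in this set, read in this assay, is a 6.8-fold higher number from compound 1 to compound 4 (0.83 log units; beyond the scatter) when 3-chloropyridin-2-yl takes the place of cyclobutylmethyl on an amide-type nitrogen. The number therefore responds to the group on this nitrogen even with the core of compound 1 unchanged, and this aromatic replacement moves it towards weaker inhibition, beyond the scatter. Nothing available accounts for the size or direction of this step.

The swap changes the ring, the chlorine and the ring nitrogen together. The compounds shown do not reveal which of these parts goes with the higher number. Going by these compounds, it also remains open where an unsubstituted phenyl, a plain pyridin-2-yl or a longer alkyl chain on this nitrogen would fall relative to compound 1 and compound 4.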